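Methylsulfanyl in place of benzylselanyl on the acylimidamide core

A few compounds are considered here, and "the series" means these few. Any claim that something is new, unique, unknown or untested is made for them only; others in the source may bear on it.

Compound 1 `CS/C(=N\C(=O)c1ccco1)NC(=O)c1ccco1` carries the methylsulfanyl group on a furoyl-substituted core. In a functional assay on MCF7 cells (Homo sapiens) for cytotoxicity, read by MTT assay, with a stated time of 72 h (a higher number here means that more compound is tolerated, a lower number that less compound is tolerated), compound 1 gives only a limit, > 100000 nM. Compound 2 `O=C(/N=C(/NC(=O)c1ccno1)[Se]Cc1ccccc1)c1ccno1` carries the benzylselanyl group on an isoxazole-substituted core. In this assay compound 2 likewise gives only a limit, > 100000 nM. Among the measured compounds shown here, compound 3 `O=C(/N=C(/NC(=O)c1cc(-c2ccccc2)nc2ccccc12)[Se]Cc1ccccc1)c1cc(-c2ccccc2)nc2ccccc12` is the one compound with a number: in this assay compound 3 gives 97000 nM, which is the only measured value here, since the other two sit at the limit of > 100000 nM in this assay, at which 2 of the 3 values shown sit.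

Compound 4 `CS/C(=N\C(=O)c1cc(-c2ccccc2)nc2ccccc12)NC(=O)c1cc(-c2ccccc2)nc2ccccc12` differs from compound 3 by a group of 2 heavy atoms (1 carbon, 1 sulfur; no ring) in place of a group of 8 heavy atoms (7 carbon, 1 selenium; one six-membered aromatic ring of carbon only), on a carbon with a double bond to nitrogen. For the measured compounds named here, no step between measured compounds is available to size this change; the swap in compound 1 and compound 2 ends in limits both ways. The step from compound 3 to compound 4 is therefore expected to be a 1.2-fold higher number from compound 3 to compound 4 (0.09 log units; within the scatter), nothing beyond the scatter. Compound 4 is estimated at 120000 nM in this assay, within 50000 nM to 300000 nM, most likely reported as a limit.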

Compound 4, concentration lethal to 50% of the cells: > 100000 nM
Compound 4: only a limit was reported (the forecaster's own chance of this, stated with the estimate: 60%); the middle value does not contradict the limit.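

On the shared core, the change from benzylselanyl to methylsulfanyl now has one readable pair, and in this assay it gives an at least 1.0-fold higher number from compound 3 to compound 4 (0.01 log units; that floor lies within the scatter). This step rests on a limit, and its floor lies within the scatter, so it fixes no size for the change. The swap takes out the selenium and the aromatic ring together, and the series remains mostly at a limit: the limit of > 100000 nM in this assay, at which 3 of the 4 values shown sit.

As far as these compounds go, whether the selenium or the ring matters stays open, and a benzylsulfanyl group would separate the two. From the compounds shown here alone, what an amine or a longer chain would do on this carbon also stays open.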